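The source may report more compounds than this note shows. Statements on the series, on what has been measured and on what is new or still open speak of the compounds shown alone.

Measured so far:
Compound 1, `CN(Cc1ccc2nccn2c1)c1nnc(-c2ccccc2)o1`, with 2.4
Compound 2, `CN(Cc1ccc2nccn2c1)c1nnc(-c2ccc(-c3ccccc3F)cc2)o1`, with 4.4

Both numbers come from a physicochemical assay for lipophilicity, at pH 7.4; a lower number here means a more polar compound, a higher number a more lipophilic compound. Compound 1 stands lowest of the two; the nearest number is that of compound 2, which lies a number 2.00 log units higher from compound 1 to compound 2 (beyond the scatter), the change there being 2-fluorophenyl in place of hydrogen on an aromatic carbon.

Compound 3, `Cc1nn(C)c(C)c1-c1ccc(-c2nnc(N(C)Cc3ccc4nccn4c3)o2)cc1`, is still to be measured in this assay. Against compound 1 it differs by 1,3,5-trimethyl-1H-pyrazol-4-yl in place of hydrogen on an aromatic carbon, the new group sitting on an aromatic carbon of a six-membered aromatic ring of carbon only, para to a large group. Among the measured compounds shown here, only one measured step bears on this change: it also put an aromatic ring onto hydrogen at such a carbon, and it was a number 2.00 log units higher from compound 1 to compound 2 (beyond the scatter). The entering group here is a five-membered aromatic ring with 2 hetero atoms and 2 hydrogen-bond acceptors rather than a 2-fluorophenyl, so the rise in this assay is expected to be clear but smaller than that step. The expected step is a number 1.20 log units higher from compound 1 to compound 3 (beyond the scatter). Compound 3 is therefore estimated at 3.6, with a range from 3 to 4.2.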

Compound 3, distribution coefficient: 3.1
Compound 3: middle estimate off by 0.50 log units, on the high side; the range from low to high includes it.
By their numbers in this assay, from the lowest: compound 1; then compound 3; then compound 2.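

On a six-membered aromatic carbon ring, at the carbon para to a large group, 1,3,5-trimethyl-1H-pyrazol-4-yl in place of hydrogen gives, in this assay, a number 0.70 log units higher from compound 1 to compound 3 (beyond the scatter), so a second ring added at this carbon also raises the number. Swapping the entering ring alone gives a number 1.30 log units lower from compound 2 to compound 3 (beyond the scatter), which shows that the size of the rise at this carbon depends on which ring enters, and not merely on a ring being present: the pyrazole ring, with its 2 hetero atoms and 2 hydrogen-bond acceptors, lands well short of the 2-fluorophenyl. Nothing measured here explains the gap between these two rings.

The compounds shown cannot separate the part played by the ring nitrogens from that of the three methyl groups on the pyrazole, a question that an unsubstituted pyrazole or a plain phenyl at the same carbon would address. They also leave open how far the number would move at this carbon with a group that is not an aromatic ring, such as an amine or a carboxylic acid.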